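Swapping Chloro for Methyl on the Triazole-Linked Phenyl

The source may report more compounds than this note shows. Statements on the series, on what has been measured and on what is new or still open speak of the compounds shown alone.

For the measured compounds named here, compound 1 `C/C(=C\CC/C(C)=C/CC[C@@H]1[C@@]2(C)CCC(=O)C(C)(C)[C@H]2CC[C@@]1(C)O)CC/C=C(\C)C(=O)OCc1cn(-c2cccc(Cl)c2)nn1` is tested in a functional assay on DU-145 cells (Homo sapiens) for antiproliferative activity, read by MTT assay, with a stated time of 48 h (a lower number here means a stronger inhibitor, a higher number a weaker inhibitor), where compound 1 gives 103000 nM, the only plain number among the three measured compounds. Compound 2 `C/C(=C\CC/C(C)=C/CC[C@@H]1[C@@]2(C)CCC(=O)C(C)(C)[C@H]2CC[C@@]1(C)O)CC/C=C(\C)C(=O)OCc1cn(-c2ccccc2F)nn1` reaches only a limit of the assay, > 150000 nM. Compound 3 `COc1ccccc1-n1cc(COC(=O)/C(C)=C/CC/C(C)=C/CC/C(C)=C/CC[C@@H]2[C@@]3(C)CCC(=O)C(C)(C)[C@H]3CC[C@@]2(C)O)nn1` likewise reaches only a limit, > 150000 nM. Both steps away from compound 1 are therefore floors rather than exact sizes: an at least 1.4-fold higher number from compound 1 to compound 2 (0.16 log units; that floor lies within the scatter), and an at least 1.4-fold higher number from compound 1 to compound 3 (0.16 log units; that floor lies within the scatter). Between compound 2 and compound 3 the step is a step that the two limits leave unreadable from compound 2 to compound 3, because of the limit of > 150000 nM in this assay, at which 2 of the 3 values shown sit.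

Compound 4 `C/C(=C\CC/C(C)=C/CC[C@@H]1[C@@]2(C)CCC(=O)C(C)(C)[C@H]2CC[C@@]1(C)O)CC/C=C(\C)C(=O)OCc1cn(-c2cccc(C)c2)nn1` differs from compound 1 by methyl in place of chloro on an aromatic carbon. The measured steps all alter this same phenyl group on the triazole, and each pushed the number up to the limit, so a change here is expected to weaken rather than strengthen inhibition, if it moves beyond the scatter at all. Compound 4 is therefore expected to give 120000 nM, with a range from 60000 nM to 250000 nM. This estimate means a step of a 1.2-fold higher number from compound 1 to compound 4 (0.07 log units; within the scatter), expected to lie within the scatter.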

Compound 4, half-maximal inhibitory concentration: 137000 nM
For compound 4 the middle estimate is 1.1-fold (0.06 log units) below the measured one; measured number inside the range.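

Methyl in place of chloro gives a 1.3-fold higher number from compound 1 to compound 4 (0.12 log units; within the scatter) in this assay, so at this place on the phenyl ring, the chloro group can be exchanged for a methyl group without a readable shift. Unlike the fluoro and methoxy compounds, compound 4 returns a plain number, which gives a second exact value for this series. Even so, the steps of an at least 1.0-fold lower number from compound 3 to compound 4 (0.03 log units; that floor lies within the scatter) and an at least 1.0-fold lower number from compound 2 to compound 4 (0.03 log units; that floor lies within the scatter) are only floors that stay inside the scatter, so these data do not separate compound 4 from either compound: the limit of > 150000 nM in this assay, at which 2 of the 4 values shown sit.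

As far as these compounds go, it remains open whether an amine, a carboxylic acid or a longer chain such as propyl at this same place would move the number beyond the scatter. From the compounds shown here alone, whether any change to this phenyl group could give a much stronger inhibitor also remains unknown.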